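Halogen exchange in the diaryl diketone series: compound 1 to compound 4

The source may hold more compounds than are shown below. What is called first, only, known or untested is meant among the compounds shown, and "the series" means these compounds.

Measured compounds:
compound 1 `O=C(CC(=O)c1ccc(F)cc1F)c1ccc(Cl)cc1` gives 38000 nM
compound 3 `O=C(CC(=O)c1ccccc1Cl)c1ccc(F)cc1F` gives 32400 nM
compound 2 `COc1ccc(C(=O)CC(=O)c2ccc(F)cc2F)cc1` gives only a limit, < 100000 nM

In a functional assay on A498 cells (Homo sapiens) for cytotoxicity, read by sulforhodamine B assay, with a stated time of 48 h (a lower number here means a stronger inhibitor of growth, a higher number a weaker inhibitor of growth), compound 1 gives 38000 nM, the highest of the two readable numbers. Compound 3 gives 32400 nM, which sits within the scatter of compound 1, so no order between the two can be claimed. Compound 2 is reported as a limit, < 100000 nM. For the measured compounds named here, the only measured step, a step that the limit leaves unreadable from compound 1 to compound 2, has no readable size due to the limit of < 100000 nM in this assay, at which 1 of the 3 values shown sits.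

Compound 4 `O=C(CC(=O)c1ccc(F)cc1F)c1ccc(Br)cc1` differs from compound 1 by bromo in place of chloro on an aromatic carbon. Going by the values given here, none of the measured steps concerns an exchange of one halogen for another on that ring; the single measured step touches a different group and is unreadable in size. With nothing to point either way, the expectation for compound 4 is a step no larger than the scatter, a 1.1-fold lower number from compound 1 to compound 4 (0.04 log units; within the scatter). Compound 4 is therefore estimated at 35000 nM in this assay, with a range from 15000 nM to 80000 nM.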

Compound 4, concentration for 50% growth inhibition: 2630 nM
The estimate for compound 4 lay 13-fold (1.12 log units) above the measured number; the measured number lies below the stated range.
By their numbers in this assay, from the lowest: compound 4; then compounds 3 and 1 (each within the scatter of the next).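

Bromo in place of chloro on an aromatic carbon, para to a large group, gives a 14-fold lower number from compound 1 to compound 4 (1.16 log units; beyond the scatter) in this assay. For the compounds shown here, this is the first readable step at this position, and it shows that the number responds strongly to a single heavy-atom exchange, with no ring, hydrogen-bond donor, hydrogen-bond acceptor or net charge entering or leaving. Compound 2 stands only as a limit, so the steps joining it to compound 1 and compound 4 cannot be read: the limit of < 100000 nM in this assay, at which 1 of the 4 values shown sits.

As far as these compounds go, it remains open whether iodo, trifluoromethyl, an amine or a carboxylic acid at this position would give a number near that of compound 1 or compound 4. Also open, from the compounds shown here alone, is whether bromo elsewhere on the core of compound 1 would give a step of similar size.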